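The source may report more compounds than this note shows. Statements on the series, on what has been measured and on what is new or still open speak of the compounds shown alone.

Of the compounds shown here, two built on the same core have been tested in an ADME assay on HEK-293T cells (Homo sapiens) for cytotoxicity, read by resazurin assay, with a stated time of 30 h; a higher number here means that more compound is tolerated, a lower number that less compound is tolerated. Compound 1 is `O=C(Nc1ccc(N=C2NCCN2)cc1)c1ccc(N=C2NCCN2)c(F)c1`. In this assay compound 1 reaches only the limit of the measurement, > 200000 nM, and gives no number. Compound 2 is `O=C(Nc1ccc(N=C2NCCN2)cc1)c1ccc(N=C2NCCN2)cc1Cl`. In this assay compound 2 likewise returns only a limit, > 200000 nM, rather than a measured value. Compound 2 therefore stands where both tested compounds sit, at the limit of > 200000 nM in this assay, at which 2 of the 2 values shown sit. Compound 3 is `O=C(Nc1ccc(N=C2NCCN2)cc1)c1ccc(N=C2NCCN2)cc1F`. It differs from compound 2 by a single change: fluoro in place of chloro on an aromatic carbon. Among the measured compounds shown here, no step between measured compounds is available, so the size of this change in this assay cannot be read from earlier pairs; no shift beyond the usual scatter is expected. For compound 3 the estimate in this assay is 300000 nM, within 150000 nM to 600000 nM, which means an expected step that the limit leaves unreadable from compound 2 to compound 3.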

Compound 3, half-maximal cytotoxic concentration: > 200000 nM
Compound 3: no number, only a limit; the forecaster's own chance of this, stated with the estimate: 85%; the middle value does not contradict the limit.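

Compound 2 and compound 3 both give only a limit, not a number, so no step can be read for fluoro in place of chloro. The compounds shown leave open what concentration of any of them would harm these cells, and whether this change makes any difference: the limit of > 200000 nM in this assay, at which 3 of the 3 values shown sit.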